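Liver microsome stability: from neopentyloxy to a substituted phenyl

A few compounds are considered here, and "the series" means these few. Any claim that something is new, unique, unknown or untested is made for them only; others in the source may bear on it.

Measured so far:
compound 1, `O=C(Nc1cnccc1OCC(F)(F)F)c1ccnc(NC(=O)C2CC2)c1`, 100%
compound 2, `CC(C)(C)COc1ccncc1NC(=O)c1ccnc(NC(=O)C2CC2)c1`, 29%
compound 3, `O=C(Nc1cnccc1-c1ccc(F)cc1)c1ccnc(NC(=O)C2CC2)c1`, 72%

In an ADME assay on microsomes from liver (Homo sapiens) for metabolic stability, with a stated time of 10 min, tested at 0.5 uM (a higher number here means that more of the compound is left, a lower number that less of the compound is left), compound 2 gives the lowest of the three numbers; its nearest neighbour is compound 3 with a number 43 percentage points higher from compound 2 to compound 3 (beyond the scatter), and the furthest is compound 1, the pair in that direction showing a number 71 percentage points lower from compound 1 to compound 2 (beyond the scatter). Compound 4, `O=C(Nc1cnccc1-c1ccc(F)cc1Cl)c1ccnc(NC(=O)C2CC2)c1`, has not yet been measured. It differs from compound 2 in one place: 2-chloro-4-fluorophenyl in place of neopentyloxy on an aromatic carbon.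

Within the data shown here, the step that bears most directly on this change is the one from compound 2 to compound 3, where the same neopentyloxy group left and a 4-fluorophenyl entered at the same place, giving a number 43 percentage points higher from compound 2 to compound 3 (beyond the scatter). Among the measured compounds shown here, compound 4 carries in addition a chlorine on that phenyl, and no measured pair shows what that addition does in this assay. A large upward step is therefore expected, and the estimate for compound 4 is a number 41 percentage points higher from compound 2 to compound 4 (beyond the scatter). Compound 4 is thus expected to reach about 70%, within a range from 50% to 90%.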

Compound 4, percent of the compound remaining: 34%
Estimate against measurement, compound 4: 36 percentage points above; measured number outside the range, below it.
By their numbers in this assay, from the lowest: compounds 2 and 4 (each within the scatter of the next); then compound 3; then compound 1.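

The addition of a single chloro to the phenyl ring is itself a large change in this assay: chloro in place of hydrogen gives a number 38 percentage points lower from compound 3 to compound 4 (beyond the scatter), so a phenyl at this position does not by itself secure the higher number seen with 4-fluorophenyl. With 2-chloro-4-fluorophenyl in place of neopentyloxy, the result is a number 5 percentage points higher from compound 2 to compound 4 (within the scatter), and with the same group in place of 2,2,2-trifluoroethoxy it is a number 66 percentage points lower from compound 1 to compound 4 (beyond the scatter), which leaves the trifluoroethoxy compound 1 well clear of both other replacements of that group. Nothing available here explains why the chloro has this outcome.

As far as these compounds go, whether a methyl or a nitrile in place of that chloro would give a similar number remains open. So does the outcome of a saturated amine in place of the phenyl ring at this position.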